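A few compounds are considered here, and "the series" means these few. Any claim that something is new, unique, unknown or untested is made for them only; others in the source may bear on it.

Compounds measured in a functional assay on cells (Platelet, Homo sapiens) for inhibition; a higher number here means a weaker inhibitor, a lower number a stronger inhibitor:
- compound 1 `CCOC(=O)c1ccc(-c2nn(C)c3ccccc23)cc1`: 270 nM
- compound 2 `CCOC(=O)c1ccc(-c2nn(Cc3cccc(Cl)c3)c3ccccc23)cc1`: 80 nM
- compound 3 `CCOC(=O)c1ccc(-c2nn(Cc3ccc(F)cc3)c3ccccc23)cc1`: 190 nM

All three share the same core; they differ only in what hangs from the saturated chain carbon bound to the aromatic nitrogen. In this assay compound 1 gives the highest number of the three, with compound 3 nearest and compound 2 furthest away: a 1.4-fold lower number from compound 1 to compound 3 (0.15 log units; within the scatter), and a 3.4-fold lower number from compound 1 to compound 2 (0.53 log units; beyond the scatter). Between the two substituted compounds, a 2.4-fold higher number from compound 2 to compound 3 (0.38 log units; beyond the scatter).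

Compound 4 `CCOC(=O)c1ccc(-c2nn(Cc3cccc(OC)c3)c3ccccc23)cc1` takes the same route as the other two substituted compounds. Its difference from compound 1 is 3-methoxyphenyl in place of hydrogen on a saturated chain carbon bound to an aromatic nitrogen. The two steps that bear on this are the ones from compound 1 to compound 2 and from compound 1 to compound 3: both add an aromatic ring at this place, one giving a modest drop in the number beyond the scatter, the other a drop that stays within it. A lower number is therefore expected for compound 4, most likely of a modest size, though it could also remain within the scatter of compound 1.

The estimate for compound 4 in this assay is 130 nM, with a range from 50 nM to 320 nM, which would correspond to an expected step of a 2.1-fold lower number from compound 1 to compound 4 (0.32 log units; beyond the scatter).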

Compound 4, half-maximal inhibitory concentration: 260 nM
Beside the measured number, compound 4's estimate is 2.0-fold (0.30 log units) below it, within the range that was stated.
By their numbers in this assay, from the lowest: compound 2; then compounds 3, 4 and 1 (each within the scatter of the next).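

Putting a 3-methoxyphenyl on this chain carbon gives no change that can be told apart in this assay (a 1.0-fold lower number from compound 1 to compound 4 (0.02 log units; within the scatter)), so adding an aromatic ring at this place does not in itself lower the number, as the earlier pair of ring-bearing compounds might have suggested. Going by these compounds alone, what the ring carries now stands out more clearly: with methoxy in place of chloro on an aromatic carbon, the gain seen with compound 2 is lost (a 3.3-fold higher number from compound 2 to compound 4 (0.51 log units; beyond the scatter)), while the 3-methoxyphenyl and the 4-fluorophenyl cannot be told apart (a 1.4-fold higher number from compound 3 to compound 4 (0.14 log units; within the scatter)), which leaves compound 2 as the only one of the ring-bearing compounds that stands clear of compound 1. No measurement shown here accounts for the gap between the chloro and methoxy compounds.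

The compounds shown leave open what a plain phenyl with no substituent would give at this place, and whether a 3-bromophenyl or a 3-trifluoromethylphenyl would read like compound 2 or like compound 4. Also open, from the compounds shown here alone, is how the number would respond to a ring bearing a dimethylamino group, or to a longer chain carrying the ring.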